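This account rests on a few compounds, and the source may have more. Where it says the series, first, only, none or still open, it means among the compounds named here.

Measured in a physicochemical assay for solubility, read by spectrophotometry; on this read-out lower numbers stand for lower solubility and higher numbers for higher solubility:
- compound 1 `O=C(Oc1ccc(-c2cc(=O)c3c(O)c(O)c(O)cc3o2)cc1)N1CCOCC1`: 15.3 ug/mL
- compound 2 `CN(C)C(=O)COc1ccc(-c2cc(=O)c3c(O)c(O)c(O)cc3o2)cc1`: 9.32 ug/mL

Compound 2, at 9.32 ug/mL, stands within the scatter of compound 1, so the two cannot be ranked. Compound 3 `CCN(CC)C(=O)Oc1ccc(-c2cc(=O)c3c(O)c(O)c(O)cc3o2)cc1` is still unmeasured and differs from compound 2 as follows: diethylcarbamoyl in place of (dimethylcarbamoyl)methyl on an oxygen on an aromatic ring. Among the compounds with values here, one measured step bears on this place, on an oxygen on an aromatic ring: a 1.6-fold lower number from compound 1 to compound 2 (0.22 log units; within the scatter). Within the data shown here, with only that step as a guide, no change beyond the scatter is expected. The expected step is a 1.2-fold lower number from compound 2 to compound 3 (0.07 log units; within the scatter). The estimate for compound 3 is 8 ug/mL, with an expected range of 3.5 ug/mL to 19 ug/mL.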

Compound 3, solubility: 9.23 ug/mL
Compound 3: the middle estimate sits 1.2-fold (0.06 log units) below what was measured; the measured number falls inside the stated range.
By their numbers in this assay, from the lowest: compounds 3, 2 and 1 (each within the scatter of the next).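

In this assay, diethylcarbamoyl in place of (dimethylcarbamoyl)methyl on an oxygen on an aromatic ring gives a 1.0-fold lower number from compound 2 to compound 3 (0.00 log units; within the scatter), and diethylamino in place of morpholin-4-yl on a carbonyl carbon gives a 1.7-fold lower number from compound 1 to compound 3 (0.22 log units; within the scatter). Within the data shown here, the scatter therefore leaves compound 1, compound 2 and compound 3 unseparated, now with a first reading on the carbonyl carbon as well. No evidence bears on a cause for these results.

Still open, on these data alone, is whether an amine or a carboxylic acid on that oxygen would give a step beyond the scatter. The same holds for a longer chain in place of diethylamino on the carbonyl carbon.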